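Pyrazole swap on the shared core: cytotoxicity outlook

The compounds below may be only part of what the source reports. "The series", "measured", "known", "first", "only" and "open" are said of these compounds alone.

Compound 3 `O=c1nc(-c2ccccc2)c2cc(-c3cn[nH]c3)ccc2[nH]1` carries a 1H-pyrazol-4-yl group on an aromatic carbon of the shared core. In an ADME assay on L6 cells (Rattus norvegicus) for cytotoxicity, read by fluorescence and resazurin assay, with a stated time of 72 h (a lower number here means that less compound is needed, a higher number that more compound is needed for the effect), compound 3 gives > 50000 nM, which is a limit of the assay and not a number. Compound 1 `Cc1ccc(-c2ccc3[nH]c(=O)nc(-c4ccccc4)c3c2)cn1` also gives > 50000 nM in this assay, again a limit and not a number. Among the compounds with values here, compound 2 `O=c1nc(-c2ccccc2)c2cc(-c3cccc(F)c3)ccc2[nH]1`, with a 3-fluorophenyl group at that carbon, is the only member with a number in this assay, at 23000 nM. The measured steps run an at least 2.1-fold lower number from compound 1 to compound 2 (0.33 log units; beyond the scatter), an at least 2.1-fold higher number from compound 2 to compound 3 (0.33 log units; beyond the scatter) and a step that the two limits leave unreadable from compound 1 to compound 3; two of the three values rest at the limit of > 50000 nM in this assay, at which 2 of the 3 values shown sit, so the series is read mostly through limits.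

Compound 4 `Cn1nccc1-c1ccc2[nH]c(=O)nc(-c3ccccc3)c2c1` is not yet measured. It differs from compound 3 by 1-methyl-1H-pyrazol-5-yl in place of 1H-pyrazol-4-yl on an aromatic carbon. Within the data shown here, no measured step exchanges one pyrazolyl for another; the step between compound 2 and compound 3 is the nearest comparison, and it only sets a floor. With compound 3 at a limit and the change confined to the five-membered ring, the expectation in this assay is a step of a number no higher from compound 3 to compound 4 (the limit leaves the size open), that is, none readable beyond the scatter. Compound 4 is expected at 50000 nM, within 20000 nM to 120000 nM, with a fair chance that only a limit is reported again.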

Compound 4, half-maximal effective concentration: > 50000 nM
Compound 4 was reported as a limit; the forecaster's own chance of this, stated with the estimate: 65%; the middle value sits exactly at the limit.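

Compound 4 gives > 50000 nM in this assay, which is a limit of the assay and not a number. The earlier compounds shown here showed this limit only for 1H-pyrazol-4-yl and 6-methylpyridin-3-yl; it now also holds for 1-methyl-1H-pyrazol-5-yl, which has 0 hydrogen-bond donors where 1H-pyrazol-4-yl has 1 and is the larger group by its heavy-atom count. Against 3-fluorophenyl, the exchange gives an at least 2.1-fold higher number from compound 2 to compound 4 (0.33 log units; beyond the scatter), so compound 2 remains the only member with a number, while the steps among compound 1, compound 3 and compound 4 cannot be read, and the series now rests largely on a single limit: the limit of > 50000 nM in this assay, at which 3 of the 4 values shown sit.

The compounds shown leave open how far any of the three groups at the limit lies from it, and so whether the methyl group or the change in attachment on the pyrazole has any effect of its own in this assay. They also leave open whether an unsubstituted phenyl, a basic amine such as an aminomethyl group, or a carboxylic acid at this aromatic carbon would give a number or another limit.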